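Trading the acid-bearing ring for a plain methoxyphenyl

A few compounds are considered here, and "the series" means these few. Any claim that something is new, unique, unknown or untested is made for them only; others in the source may bear on it.

Three compounds share a core and differ in the aryl ether at the far end. Compound 1 `Cc1ncc(OCCCCOc2ccc(C(=O)CC(C)(C)C)c(O)c2C)cc1C(=O)O` gives 28 nM in an assay for positive allosteric modulation of metabotropic glutamate receptor 2 (Rattus norvegicus) (a lower number here means that less compound is needed, a higher number that more compound is needed for the effect), and compound 2 `COc1cc(C(=O)O)ccc1OC[C@H](C)COc1ccc(C(=O)CC(C)(C)C)c(O)c1C` gives 28 nM. For the measured compounds named here, compound 3 `Cc1c(OC[C@@H](C)COc2ccc(C(=O)O)cc2Cl)ccc(C(=O)CC(C)(C)C)c1O` gives 477 nM, the highest of the three numbers; the only single-point step to it, a 17-fold higher number from compound 2 to compound 3 (1.23 log units; beyond the scatter), is a large one. Compound 4 `COc1cccc(OC[C@H](C)COc2ccc(C(=O)CC(C)(C)C)c(O)c2C)c1` differs from compound 3 by 3-methoxyphenyl in place of 4-carboxy-2-chlorophenyl on an oxygen on a saturated carbon. Going by the values given here, no measured step reaches across this change: the step from compound 2 to compound 3 concerns only the chloro and methoxy exchange, and the carboxylic acid itself is present in every measured compound, so there is no information on removing it. The methoxy group that returns resembles compound 2, yet the acid is gone. Compound 4 is therefore expected to give a higher number, estimated as a 3.1-fold higher number from compound 3 to compound 4 (0.50 log units; beyond the scatter), with much uncertainty. The estimate for compound 4 is 1500 nM, ranging from 300 nM to 8000 nM.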

Compound 4, half-maximal effective concentration: "not active" (no number reported)
No number was reported for compound 4, so the estimate cannot be set against anything.
By their numbers in this assay, from the lowest: compounds 1 and 2 (each within the scatter of the next); then compound 3.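

In this assay, for the compounds shown here, compound 4 is reported only as not active, with no number, so no step from compound 3 to compound 4 can be read. No measurement shown here accounts for this result. The compounds shown leave open whether losing the carboxylic acid or introducing 3-methoxyphenyl matters more.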